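This account rests on a few compounds, and the source may have more. Where it says the series, first, only, none or still open, it means among the compounds named here.

Measured so far:
compound 1 `O=C(Nc1ccccc1)N1CCc2[nH]nc(-c3ccccc3)c2C1` — 192 mL/min/kg
compound 2 `C[C@H]1Cc2[nH]nc(-c3ccccc3)c2CN1C(=O)Nc1cccc(Cl)c1` — 15 mL/min/kg

In an ADME assay on microsomes (Homo sapiens) for metabolic stability (on this read-out lower numbers stand for slow clearance and higher numbers for fast clearance), compound 2 holds the lowest of the two numbers, with compound 1 giving a number well beyond the scatter above it. Compound 3 `C[C@@H]1Cc2[nH]nc(-c3ccccc3)c2CN1C(=O)Nc1cccc(Cl)c1` differs from compound 2 only as follows: the two compounds have the same atoms and bonds and differ only in configuration as drawn: 1 of 1 stereo elements differ; a stereocentre at a saturated ring carbon is drawn S in compound 2 and R in compound 3. Among the measured compounds shown here, no measured pair here isolates a change in configuration, so no step size is known for it. The expectation is a step from compound 2 to compound 3 of a 1.7-fold higher number from compound 2 to compound 3 (0.22 log units; within the scatter), within the usual scatter, with the risk tilted toward a faster number. Compound 3 is therefore estimated at 25 mL/min/kg, ranging from 10 mL/min/kg to 80 mL/min/kg.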

Compound 3, clearance: 43 mL/min/kg
Compound 3: the middle estimate sits 1.7-fold (0.24 log units) below what was measured; the measured number falls inside the stated range.
By their numbers in this assay, from the lowest: compound 2; then compound 3; then compound 1.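

In this assay, the stereocentre at the saturated ring carbon is not neutral: going from S to R gives a 2.9-fold higher number from compound 2 to compound 3 (0.46 log units; beyond the scatter). The S configuration as drawn therefore gives the slower clearance of this pair. This is the only measured step for a change in configuration in the series, and it can be assigned to the stereocentre alone: the fact that compounds 2 and 3 differ only in the configuration as drawn

Compound 1 differs from compound 2 in more than one place, so the contribution of the substituent on this carbon cannot be read separately. On these data alone, whether the same S over R order holds for a longer chain such as ethyl, or for a hydroxymethyl group, at this carbon remains open.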